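Expected Effect of Adding a Methoxy Group

The compounds below may be only part of what the source reports. "The series", "measured", "known", "first", "only" and "open" are said of these compounds alone.

Compound 1, `COc1ccc(C2CC(c3ccccc3)=NN2C2=NC(=O)/C(=C3\C(=O)Nc4ccccc43)S2)cc1`, gives 3450 nM in a functional assay on cells (Cancer cell lines, Homo sapiens) for cytotoxicity, read by sulforhodamine B assay, with a stated time of 48 h; on this read-out higher numbers stand for weaker inhibition of growth and lower numbers for stronger inhibition of growth.
Compound 2, `COc1ccc(C2=NN(C3=NC(=O)/C(=C4\C(=O)Nc5ccccc54)S3)C(c3ccc(OC)cc3)C2)cc1`, gives 89200 nM.
Compound 3, `O=C1N=C(N2N=C(c3ccccc3)CC2c2ccc(Cl)cc2)S/C1=C1/C(=O)Nc2ccccc21`, gives 500 nM.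

Of these three, compound 3 gives the lowest number, that is, the strongest growth inhibition, with every other compound well beyond the scatter above it. Compound 4, `COc1ccc(C2=NN(C3=NC(=O)/C(=C4\C(=O)Nc5ccccc54)S3)C(c3ccc(Cl)cc3)C2)cc1`, differs from compound 3 by methoxy in place of hydrogen on an aromatic carbon. The same change has been measured once in this series: a 26-fold higher number from compound 1 to compound 2 (1.41 log units; beyond the scatter), a large weakening. The other measured step, a 6.9-fold lower number from compound 1 to compound 3 (0.84 log units; beyond the scatter), concerns a different group and does not bear directly on this change. Because a 26-fold higher number from compound 1 to compound 2 (1.41 log units; beyond the scatter) was large, a large rise in the number is expected for compound 4, a 20-fold higher number from compound 3 to compound 4 (1.30 log units; beyond the scatter). Compound 4 is therefore estimated at 10000 nM, within a range of 2000 nM to 50000 nM.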

Compound 4, concentration for total growth inhibition: 100000 nM
Compound 4: middle estimate off by 10-fold (1.00 log units), on the low side; the whole stated range lies below it.
By their numbers in this assay, from the lowest: compound 3; then compound 1; then compounds 2 and 4 (each within the scatter of the next).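

The change from phenyl to 4-methoxyphenyl weakens growth inhibition again, this time with a 200-fold higher number from compound 3 to compound 4 (2.30 log units; beyond the scatter), so its size depends on the core that carries it: the same change on two cores in this assay, a 26-fold higher number (1.41 log units; beyond the scatter) from compound 1 to compound 2 and a 200-fold higher number (2.30 log units; beyond the scatter) from compound 3 to compound 4, 7.7-fold (0.89 log units) apart, beyond the scatter of two such steps. The advantage of chloro in place of methoxy also disappears once the 4-methoxyphenyl is present, with a 1.1-fold higher number from compound 2 to compound 4 (0.05 log units; within the scatter): the same change on two cores in this assay, a 6.9-fold lower number (0.84 log units; beyond the scatter) from compound 1 to compound 3 and a 1.1-fold higher number (0.05 log units; within the scatter) from compound 2 to compound 4, 7.7-fold (0.89 log units) apart, beyond the scatter of two such steps. The two changes therefore do not act independently in these four compounds.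

The compounds shown leave open whether another group in the same place, such as an amine or a carboxylic acid, would cost as much as methoxy.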